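The source may hold more compounds than are shown below. What is called first, only, known or untested is meant among the compounds shown, and "the series" means these compounds.

Measured compounds in an ADME assay on HEL cells (Homo sapiens) for cytotoxicity, with a stated time of 3 days; a higher number here means that more compound is tolerated, a lower number that less compound is tolerated:
Compound 1 `CCC1(Cc2ccccc2)OS(=O)(=O)C=C1OCc1ccc(Cl)cc1` gives >= 50000 nM in this assay; this value is a limit of the assay, not a number.
Compound 2 `C=CCOC1=CS(=O)(=O)OC1(CC)Cc1ccccc1` gives 80000 nM in this assay.
Compound 3 `CCC1(Cc2ccccc2)OS(=O)(=O)C=C1OCCc1ccccc1` gives >= 20000 nM in this assay; this value is a limit of the assay, not a number.

Compound 1 stands only at a limit, namely (the limit of >= 50000 nM in this assay, at which 1 of the 3 values shown sits); one further value shown is also a limit, (the limit of >= 20000 nM in this assay, at which 1 of the 3 values shown sits). Among the three measured compounds, the step that the limit leaves unreadable from compound 1 to compound 2 is not readable in size, nor is a step that the two limits leave unreadable from compound 1 to compound 3, nor a step that the limit leaves unreadable from compound 2 to compound 3. All three steps concern the group on a saturated chain carbon bound to an oxygen on an unsaturated carbon and leave the aromatic substituent untouched.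

Compound 4 `CCC1(Cc2ccccc2)OS(=O)(=O)C=C1OCc1ccc(C(C)(C)C)cc1` differs from compound 1 by tert-butyl in place of chloro on an aromatic carbon. Going by the values given here, no measured step bears directly on this change, and those measured are unreadable, so no size of step in this assay can be derived from them. Given that every value so far sits high in this assay, no step beyond the scatter is expected, an at least 1.2-fold lower number from compound 1 to compound 4 (0.09 log units; that floor lies within the scatter). Compound 4 is estimated at 40000 nM, with a range of 10000 nM to 100000 nM.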

Compound 4, minimum cytotoxic concentration: >= 400000 nM
Compound 4 ended at the assay's limit (the forecaster's own chance of this, stated with the estimate: 50%); middle value at least 10-fold (1.00 log units) away from the limit.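

In this assay compound 4 gives >= 400000 nM, a limit and not a number. Compound 1 also stands at a limit, so no step can be read between compound 1 and compound 4. The compounds shown leave open the size of any change when tert-butyl replaces chloro on an aromatic carbon.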